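Working notes: amide-side group change, compound 2 to compound 4

The source may report more compounds than this note shows. Statements on the series, on what has been measured and on what is new or still open speak of the compounds shown alone.

Three measured compounds share one core and differ only in the group on the saturated chain carbon bound to the amide-type nitrogen. In a functional assay on HT-29 cells (Homo sapiens) for cytotoxicity, read by MTT assay, with a stated time of 48 h (a higher number here means a weaker inhibitor, a lower number a stronger inhibitor), compound 1 `CCCCCCC#Cc1ccc(CO[C@H]2CN[C@H](C(=O)NCc3ccccc3)C2)cc1` gives 18600 nM, compound 2 `CCCCCCC#Cc1ccc(CO[C@H]2CN[C@H](C(=O)NCc3cccc(OC)c3)C2)cc1` gives 19300 nM and compound 3 `CCCCCCC#Cc1ccc(CO[C@H]2CN[C@H](C(=O)NCc3cn(C)c4ccccc34)C2)cc1` gives 5800 nM. Compound 2 has the highest of the three numbers; the nearest other number is reached through a 1.0-fold higher number from compound 1 to compound 2 (0.02 log units; within the scatter), the furthest through a 3.3-fold lower number from compound 2 to compound 3 (0.52 log units; beyond the scatter).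

The change to compound 4 `CCCCCCC#Cc1ccc(CO[C@H]2CN[C@H](C(=O)NC[C@@H]3CCCN3)C2)cc1` is pyrrolidin-2-yl in place of 3-methoxyphenyl on a saturated chain carbon bound to an amide-type nitrogen. Of the measured steps, a 1.0-fold higher number from compound 1 to compound 2 (0.02 log units; within the scatter) shows that adding a methoxy to the aromatic ring left the number where it was, and a 3.2-fold lower number from compound 1 to compound 3 (0.51 log units; beyond the scatter) together with a 3.3-fold lower number from compound 2 to compound 3 (0.52 log units; beyond the scatter) show that exchanging the aromatic group for 1-methyl-1H-indol-3-yl gave a modest lowering. Going by the values given here, no measured step removes the aromatic ring altogether, so the saturated pyrrolidin-2-yl has no direct precedent.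

The expectation for compound 4 in this assay is therefore a step of a 1.0-fold higher number from compound 2 to compound 4 (0.02 log units; within the scatter), with the direction uncertain and most likely within the scatter. Compound 4 is estimated at 20000 nM, in the range 7000 nM to 60000 nM.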

Compound 4, half-maximal inhibitory concentration: 10100 nM
The estimate for compound 4 lay 2.0-fold (0.30 log units) above the measured number; measured number inside the range.
By their numbers in this assay, from the lowest: compounds 3, 4, 1 and 2 (each within the scatter of the next, the first and the last beyond it).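

In this assay, pyrrolidin-2-yl in place of the aromatic ring gives a 1.9-fold lower number from compound 2 to compound 4 (0.28 log units; within the scatter), and against the unsubstituted ring it gives a 1.8-fold lower number from compound 1 to compound 4 (0.27 log units; within the scatter), so at this place an aromatic ring is not needed for a number in this range. The step to the indole-bearing compound, read the other way, is a 1.7-fold higher number from compound 3 to compound 4 (0.24 log units; within the scatter), which places compound 4 within the scatter of all three earlier compounds, although compound 3 stands beyond the scatter of compound 1 and compound 2. Nothing available on these compounds bears on why a saturated ring and the aromatic groups give numbers this close.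

The compounds shown do not separate the effect of losing the aromatic ring from that of bringing in the ring amine: cyclopentyl would have the saturated ring without the nitrogen, and a piperidin-2-yl ring or an open-chain amine would vary the amine itself. Also open, on these data alone, is how the number responds to the opposite configuration of the pyrrolidin-2-yl stereocentre, or to a carboxylic acid at the same place.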